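The compounds below may be only part of what the source reports. "The series", "measured", "known", "first", "only" and "open" are said of these compounds alone.

Compound 1 `O=c1c(O)c(-c2ccccc2)oc2cc(OCc3ccccc3[N+](=O)[O-])cc(O)c12`: 32000 nM
Compound 2 `COc1ccccc1COc1cc(O)c2c(=O)c(O)c(-c3ccccc3)oc2c1`: > 100000 nM
Compound 3 `O=c1c(O)c(-c2ccccc2)oc2cc(OCc3cccc(Br)c3)cc(O)c12`: > 100000 nM

Going by the values given here, in an ADME assay on Huh-5-2 cells (Homo sapiens) for cytotoxicity, read by WST assay, with a stated time of 3 days (a higher number here means that more compound is tolerated, a lower number that less compound is tolerated), compound 1 gives 32000 nM, the only number among the three values shown. For compound 2 the assay reports only a limit, > 100000 nM. For compound 3 the assay likewise reports only a limit, > 100000 nM. Both steps away from compound 1 therefore read as increases: an at least 3.1-fold higher number from compound 1 to compound 2 (0.49 log units; beyond the scatter) and an at least 3.1-fold higher number from compound 1 to compound 3 (0.49 log units; beyond the scatter). Between the two limits the step is not readable: a step that the two limits leave unreadable from compound 2 to compound 3.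

Compound 4 `N#Cc1cccc(COc2cc(O)c3c(=O)c(O)c(-c4ccccc4)oc3c2)c1` is not yet measured. It differs from compound 1 by 3-cyanophenyl in place of 2-nitrophenyl on a saturated chain carbon bound to an oxygen on an aromatic ring. Both measured replacements of the 2-nitrophenyl group, whether on the ring substituent or on the whole benzyl arm, moved the value upward, and two of three compounds sit at the limit (the limit of > 100000 nM in this assay, at which 2 of the 3 values shown sit). The step from compound 1 to compound 4 is therefore expected to be upward as well, a 3.1-fold higher number from compound 1 to compound 4 (0.49 log units; beyond the scatter). Compound 4 is accordingly estimated at 100000 nM, within a range of 40000 nM to 300000 nM, with a fair chance that only a limit is reported.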

Compound 4, half-maximal cytotoxic concentration: 72000 nM
Estimate against measurement, compound 4: 1.4-fold (0.14 log units) above; the range from low to high includes it.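

In this assay, 3-cyanophenyl gives the first measured size for a replacement of 2-nitrophenyl on this saturated chain carbon: a 2.3-fold higher number from compound 1 to compound 4 (0.35 log units; beyond the scatter). Compound 2 and compound 3 are each reported only as a limit, whereas compound 4 has a measured number, so a change at this place need not carry a compound to that limit: the limit of > 100000 nM in this assay, at which 2 of the 4 values shown sit. Set against those limits, the remaining steps read an at least 1.3-fold lower number from compound 3 to compound 4 (0.14 log units; that floor lies within the scatter) and an at least 1.3-fold lower number from compound 2 to compound 4 (0.14 log units; that floor lies within the scatter), which establishes no order among these three compounds.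

The compounds shown leave open how far compound 2 and compound 3 lie beyond their limits, and so how large the change from bromo to cyano really is. They also leave open how an amine or a carboxylic acid on the benzyl ring would read in this assay.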